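Series notes: trifluoromethyl ketone thiophenes, five-membered heteroaryl variation

A few compounds are considered here, and "the series" means these few. Any claim that something is new, unique, unknown or untested is made for them only; others in the source may bear on it.

Measured so far:
compound 1 `O=C(c1ccc(-c2ncc(-c3ccccc3)s2)s1)C(F)(F)F` — 1500 nM
compound 2 `O=C(c1ccc(-c2nc(Cc3cccs3)no2)s1)C(F)(F)F` — 15 nM
compound 3 `O=C(c1ccc(-c2nc(CS(=O)(=O)c3cccs3)no2)s1)C(F)(F)F` — 35 nM

All three share the trifluoromethyl ketone on a thiophene and are compared in an assay for inhibition of histone deacetylase 4 (Homo sapiens); on this read-out lower numbers stand for stronger inhibition and higher numbers for weaker inhibition. Compound 2 gives the lowest number of the three. Its nearest neighbour is compound 3, reached by a 2.3-fold higher number from compound 2 to compound 3 (0.37 log units; beyond the scatter). Among the compounds with values here, compound 1, which differs from compound 2 in more than one place, sits far above both; its value and that of compound 2 show a wide gap, but no single-change step links them.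

Compound 4 `Cc1cccc(-c2noc(-c3ccc(C(=O)C(F)(F)F)s3)n2)c1` is the next candidate. Relative to compound 2 the change is 3-methylphenyl in place of (thiophen-2-yl)methyl on an aromatic carbon. Within the data shown here, only one measured step touches the same aromatic carbon: a 2.3-fold higher number from compound 2 to compound 3 (0.37 log units; beyond the scatter), which swapped the chain attachment while keeping the thiophene and moved the number modestly upward. Among the measured compounds shown here, no measured pair exchanges a thiophene-bearing chain for an aryl ring bound directly to that carbon, so the direction is not fixed by the data. Given that the one neighbouring change cost a modest amount, a comparable or somewhat larger rise is expected for compound 4, as a 2.7-fold higher number from compound 2 to compound 4 (0.43 log units; beyond the scatter). The estimate for compound 4 is 40 nM, within a range of 10 nM to 160 nM.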

Compound 4, half-maximal inhibitory concentration: 280 nM
Estimate against measurement, compound 4: 7.0-fold (0.85 log units) below; measured number outside the range, above it.
By their numbers in this assay, from the lowest: compound 2; then compound 3; then compound 4; then compound 1.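

In this assay, 3-methylphenyl in place of (thiophen-2-yl)methyl on the aromatic carbon between two ring nitrogen atoms gives a 19-fold higher number from compound 2 to compound 4 (1.27 log units; beyond the scatter). This is a large step, whereas a 2.3-fold higher number from compound 2 to compound 3 (0.37 log units; beyond the scatter) was modest, so the read-out at this position is far more sensitive to this exchange than the sulfonyl change alone indicated. The data available offer no explanation for the size of this step.

The exchange combines three changes: the saturated chain carbon is lost, the five-membered aromatic ring with one hetero atom gives way to a six-membered aromatic ring of carbon only, and a methyl group is added, so the compounds shown do not say which of these accounts for the rise. A benzyl group or an unsubstituted phenyl ring on the same carbon would help to separate these contributions, and a longer chain carrying the thiophene would show whether the distance of the ring from this carbon matters.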